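The source may report more compounds than this note shows. Statements on the series, on what has been measured and on what is new or still open speak of the compounds shown alone.

Of the compounds shown here, two with a shared core have been measured in an assay on isolated protein for inhibition of serine/threonine-protein kinase PLK1 (Homo sapiens), read by radiometric assay and 33P incorporation, with a stated time of 40 min, tested at 20 uM, in the presence of a further agent that is not named here; a higher number here means more inhibition at the concentration tested (going by the name of the read-out), a lower number less inhibition. Compound 1 `CCNc1cc(-c2ccc(NC(=O)Nc3ccccc3Cl)cc2C)ccn1` gives 49.2%, while compound 2 `CCNc1cc(-c2ccc(NC(=O)Nc3ccc(C(F)(F)F)cc3)cc2C(F)(F)F)ccn1` gives 82.9%, the higher of the two numbers by a margin beyond the usual scatter. Compound 3 `CCNc1cc(-c2ccc(NC(=O)Nc3ccccc3Cl)cc2C(F)(F)F)ccn1` has not yet been measured. It differs from compound 2 in one place: 2-chlorophenyl in place of 4-(trifluoromethyl)phenyl on an amide-type nitrogen. Since compound 1 carries this same 2-chlorophenyl group and stands lower, a drop from compound 2 to compound 3 is expected, a number 20.9 percentage points lower from compound 2 to compound 3 (beyond the scatter), though a second difference between compound 1 and compound 2 clouds the picture. Compound 3 is estimated at 62%, within 42% to 80%.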

Compound 3, a percentage reported as inhibition, at one concentration (the size of the read-out at that concentration, not a potency): 71.6%
Compound 3: middle estimate off by 9.6 percentage points, on the low side; the range from low to high includes it.
By their numbers in this assay, from the lowest: compound 1; then compound 3; then compound 2.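

Compound 3 separates the two differences that were mixed between compound 1 and compound 2, and each one alone moves the number in this assay beyond the scatter. Putting 2-chlorophenyl in place of 4-(trifluoromethyl)phenyl on the amide-type nitrogen gives a number 11.3 percentage points lower from compound 2 to compound 3 (beyond the scatter) while putting trifluoromethyl in place of methyl on an aromatic carbon gives a number 22.4 percentage points higher from compound 1 to compound 3 (beyond the scatter) in the same assay. Nothing measured here explains why either change acts as it does. Still open, from the compounds shown here alone, is how a cyclohexyl group would behave on that nitrogen, and how a methoxy group would behave in place of trifluoromethyl.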